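High clearance in the sulfamide series of fluorobenzyl amides

A few compounds are considered here, and "the series" means these few. Any claim that something is new, unique, unknown or untested is made for them only; others in the source may bear on it.

Compound 1 `Cn1c(C2CCOCC2)nc(C(=O)NCc2ccc(F)cc2N2CCN(C(C)(C)C)S2(=O)=O)c(O)c1=O`: 41 mL/min/kg
Compound 2 `Cn1c(C2CCOC2)nc(C(=O)NCc2ccc(F)cc2-n2cncn2)c(O)c1=O`: 47 mL/min/kg
Compound 3 `Cn1c(C2CCOCC2)nc(C(=O)NCc2ccc(F)cc2)c(O)c1=O`: 2.6 mL/min/kg

In an ADME assay on the whole organism (strain Sprague-Dawley) for pharmacokinetics, with Rattus norvegicus as the target, at a dose of 1 mg/kg by the intravenous route (a lower number here means slower removal, a higher number faster removal of the compound), compound 2 gives 47 mL/min/kg, the highest of the three numbers. Compound 1 is its nearest neighbour and compound 3 lies far lower. The step from compound 2 to compound 4 `Cn1c(C2CCOC2)nc(C(=O)NCc2ccc(F)cc2N2CCN(C(C)(C)C)S2(=O)=O)c(O)c1=O` is a group of 11 heavy atoms (6 carbon, 2 nitrogen, 2 oxygen, 1 sulfur; one five-membered non-aromatic ring with 3 hetero atoms) in place of a group of 5 heavy atoms (2 carbon, 3 nitrogen; one five-membered aromatic ring with 3 hetero atoms), on an aromatic carbon.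

Among the measured compounds shown here, the one measured step that bears on this change is the one in which the same entering group is stripped away: a 16-fold lower number from compound 1 to compound 3 (1.20 log units; beyond the scatter). It shows that a compound carrying this group sits at the fast end of this assay, while a compound bearing only a hydrogen at that position sits at the slow end. Compound 2, which carries the leaving group at the same place, already sits at the fast end as well. A swap of one fast-end group for another is therefore expected to move the number little, if at all, with a 1.1-fold lower number from compound 2 to compound 4 (0.05 log units; within the scatter) expected to stay within the scatter.

Compound 4 is thus estimated at 42 mL/min/kg, with a likely range from 20 mL/min/kg to 85 mL/min/kg.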

Compound 4, clearance: 31 mL/min/kg
Estimate against measurement, compound 4: 1.4-fold (0.13 log units) above; low and high end bracket the measured number.
By their numbers in this assay, from the lowest: compound 3; then compounds 4, 1 and 2 (each within the scatter of the next).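

Swapping the 1H-1,2,4-triazol-1-yl group for the larger non-aromatic ring on this aromatic carbon gives a 1.5-fold lower number from compound 2 to compound 4 (0.18 log units; within the scatter) in this assay and so does not separate the two groups, even though they differ in size and ring type. The oxolan-3-yl and oxan-4-yl groups cannot be told apart either when this larger ring is present, with a 1.3-fold lower number from compound 1 to compound 4 (0.12 log units; within the scatter) as the step between them. Nothing given here explains why any of these compounds is removed at the rate it is.

On these data alone, it remains open whether a hydrogen on this aromatic carbon would also give a low number alongside oxolan-3-yl, as it does alongside oxan-4-yl in compound 3. A small group such as methoxy or a primary amine at the same place could show how much of a substituent is enough to reach the fast end.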